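Notes on an amide-to-sulfonamide exchange in the series

The source may report more compounds than this note shows. Statements on the series, on what has been measured and on what is new or still open speak of the compounds shown alone.

Measured so far:
- compound 1, `O=C(CO)NC[C@@H]1CCCc2cc(S(=O)(=O)c3cccc(F)c3)ccc21`: in an assay on isolated protein for displacement of a labelled ligand from 5-hydroxytryptamine receptor 6 (Homo sapiens) (a higher number here means a weaker inhibitor, a lower number a stronger inhibitor), compound 1 gives 0.1 nM
- compound 2, `CC(C)(O)C(=O)NC[C@@H]1CCCc2cc(S(=O)(=O)c3cccc(F)c3)ccc21`: in this assay compound 2 gives 2 nM

Within the data shown here, compound 2 holds the higher of the two numbers; the only step in hand is a 20-fold higher number from compound 1 to compound 2 (1.30 log units; beyond the scatter), so a small change on the carbonyl side chain already moved the number well beyond the scatter.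

Compound 3, `CN(C[C@@H]1CCCc2cc(S(=O)(=O)c3cccc(F)c3)ccc21)S(C)(=O)=O`, carries methyl(methylsulfonyl)amino in place of ((1-hydroxy-1-methylethyl)carbonyl)amino on a saturated chain carbon bound to a saturated ring carbon. Among the measured compounds shown here, no measured step covers an exchange of this kind; the step from compound 1 to compound 2 shows only that this part of the molecule is sensitive, not which way a sulfonamide would go. The expectation for compound 3 is therefore a step of a 2.0-fold higher number from compound 2 to compound 3 (0.30 log units; within the scatter) in this assay, with wide uncertainty in both directions. Compound 3 is estimated at 4 nM, within 0.5 nM to 30 nM.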

Compound 3, inhibition constant: 0.398 nM
Beside the measured number, compound 3's estimate is 10-fold (1.00 log units) above it; the measured number lies below the stated range.
By their numbers in this assay, from the lowest: compound 1; then compound 3; then compound 2.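

In this assay, the exchange of ((1-hydroxy-1-methylethyl)carbonyl)amino for methyl(methylsulfonyl)amino gives a 5.0-fold lower number from compound 2 to compound 3 (0.70 log units; beyond the scatter), so this place on the saturated chain carbon accepts a group with 0 hydrogen-bond donors and no carbonyl. The same group set against the ((hydroxymethyl)carbonyl)amino of compound 1 gives a 4.0-fold higher number from compound 1 to compound 3 (0.60 log units; beyond the scatter), which leaves compound 3 ranked inside the range of the two amides rather than outside it. Nothing at hand explains either step.

Compound 3 differs from both amides in the sulfonyl and in the methyl on nitrogen together, so the shares of these two features in the steps stay unresolved. A methylsulfonylamino group with a hydrogen on nitrogen, or an ethylsulfonyl group in place of methylsulfonyl, would bear directly on that question.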